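The source may hold more compounds than are shown below. What is called first, only, known or untested is meant among the compounds shown, and "the series" means these compounds.

Four compounds that share a large common core but end in a different chain and ring are compared here. Compound 1 `COc1cc(OC)c2c(=O)c(OCCCOc3ccccc3/C=C/C(=O)/C=C/c3ccccn3)c(-c3cc(OC)c(OC)c(OC)c3)oc2c1` and compound 2 `COc1cc(OC)c2c(=O)c(OCCCOc3ccccc3/C=C/C(=O)/C=C/c3scnc3C)c(-c3cc(OC)c(OC)c(OC)c3)oc2c1` carry the same chain; in a functional assay on U-87MG ATCC cells for antiproliferative activity against U-87 MG (Homo sapiens), read by MTT assay, with a stated time of 48 h (a lower number here means a stronger inhibitor, a higher number a weaker inhibitor), compound 1 gives 3930 nM and compound 2 gives 9630 nM. The change that separates them is pyridin-2-yl in place of 4-methyl-1,3-thiazol-5-yl on a double-bonded chain carbon bound to a double-bonded chain carbon, and it produced a 2.5-fold lower number from compound 2 to compound 1 (0.39 log units; beyond the scatter). Compound 3 `COc1cc(OC)c2c(=O)c(OCCCCOc3ccc(/C=C/C(=O)/C=C/c4scnc4C)cc3)c(-c3cc(OC)c(OC)c(OC)c3)oc2c1` has a different linker and a different attachment pattern on its middle ring; how its core differs from that of compound 2 is not broken down here. In this assay compound 3 gives 58700 nM, the highest number of the three. Compound 4 `COc1cc(OC)c2c(=O)c(OCCCCOc3ccc(/C=C/C(=O)/C=C/c4ccccn4)cc3)c(-c3cc(OC)c(OC)c(OC)c3)oc2c1` has not yet been tested. It differs from compound 3 by pyridin-2-yl in place of 4-methyl-1,3-thiazol-5-yl on a double-bonded chain carbon bound to a double-bonded chain carbon, the same change as that from compound 2 to compound 1. Because that change gave a 2.5-fold lower number from compound 2 to compound 1 (0.39 log units; beyond the scatter), a step of about the same size is expected here, a 2.5-fold lower number from compound 3 to compound 4 (0.40 log units; beyond the scatter), though it rests on one pair only. Compound 4 is therefore estimated at 23500 nM in this assay, between 9000 nM and 60000 nM.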

Compound 4, half-maximal inhibitory concentration: 4690 nM
Compound 4: middle estimate off by 5.0-fold (0.70 log units), on the high side, and the stated range ends above it.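

In this assay, putting pyridin-2-yl in place of 4-methyl-1,3-thiazol-5-yl gives a 13-fold lower number from compound 3 to compound 4 (1.10 log units; beyond the scatter), a large step in the same direction as the one seen on the other core. Among the compounds shown here, the direction of the change therefore carried over from one core to the other, but its size did not: the same change on two cores in this assay, a 2.5-fold lower number (0.39 log units; beyond the scatter) from compound 2 to compound 1 and a 13-fold lower number (1.10 log units; beyond the scatter) from compound 3 to compound 4, 5.1-fold (0.71 log units) apart, beyond the scatter of two such steps With only two pairs, this shows that a step measured on one core cannot safely be copied in size to another, but it does not show why the two steps differ or how large the step would be on a third core.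

The cores of these pairs differ in both the linker and the attachment pattern on the middle ring, so the compounds shown cannot say which of the two matters for the size of the step. They also leave open how a different end group, such as a plain phenyl ring or a pyridin-3-yl ring, would behave on either core.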